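This account rests on a few compounds, and the source may have more. Where it says the series, first, only, none or still open, it means among the compounds named here.

Three compounds have been measured in a functional assay; a higher number here means a weaker inhibitor, a lower number a stronger inhibitor:

Compound 1 `O=[N+]([O-])c1ccc(-c2nnc(C3CCc4cc(F)ccc4O3)o2)cc1`: 84800 nM
Compound 2 `Fc1ccc2c(c1)CCC(c1nnc(-c3ccccc3)o1)O2`: 85900 nM
Compound 3 `Fc1ccc2c(c1)CCC(c1nnc(-c3ccccc3Cl)o1)O2`: 88000 nM

On these numbers compound 2 stands second highest of the three, but the spread is slight: the step of a 1.0-fold higher number from compound 1 to compound 2 (0.01 log units; within the scatter) and the step of a 1.0-fold higher number from compound 2 to compound 3 (0.01 log units; within the scatter) both lie within the scatter, so no order among compounds 1, 2 and 3 can be claimed.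

Compound 4 `Fc1ccc2c(c1)CCC(c1nnc(-c3ccc(Cl)cc3)o1)O2` differs from compound 2 by chloro in place of hydrogen on an aromatic carbon.

The measured step that bears most directly on this change is a 1.0-fold higher number from compound 2 to compound 3 (0.01 log units; within the scatter), where a chloro also replaced hydrogen on an aromatic carbon of the same ring and left the read-out within the scatter. The step of a 1.0-fold higher number from compound 1 to compound 2 (0.01 log units; within the scatter) likewise showed that a change on that ring made no difference beyond the scatter. On this basis no step beyond the scatter is expected for compound 4: the expected step is a 1.0-fold higher number from compound 2 to compound 4 (0.00 log units; within the scatter). Compound 4 is therefore estimated at 86000 nM, with a range from 43000 nM to 172000 nM.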

Compound 4, half-maximal inhibitory concentration: 85900 nM
Beside the measured number, compound 4's estimate is 1.0-fold (0.00 log units) above it; the range from low to high includes it.
By their numbers in this assay, from the lowest: compounds 1, 2, 4 and 3 (each within the scatter of the next).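

Going by these compounds alone, with chloro in place of hydrogen para to a large group, this assay gives no change at the digits printed from compound 2 to compound 4 (within the scatter), so this position, which the earlier compounds had tested only with nitro, now also has a chloro result that stays within the scatter. The new compound also allows two comparisons that were not available before: 4-chlorophenyl in place of 2-chlorophenyl gives a 1.0-fold lower number from compound 3 to compound 4 (0.01 log units; within the scatter), and chloro in place of nitro at the same position gives a 1.0-fold higher number from compound 1 to compound 4 (0.01 log units; within the scatter), so neither the place of the chloro nor the choice between these two groups separates the compounds. No measurement shown offers an explanation for this flat result. The compounds shown leave open whether an amine or a carboxylic acid at this position would move the read-out beyond the scatter. All the changes shown lie on the phenyl ring, so the effect of changing the shared core, including its fluoro, also remains open.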